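Trimming the Ketone Side Chain in Glutamate Receptor Modulators

This account rests on a few compounds, and the source may have more. Where it says the series, first, only, none or still open, it means among the compounds named here.

Compound 1 `Cc1cc(C(=O)O)ccc1OCCCCOc1ccc(C(=O)CC(C)C)c(O)c1C`: 192 nM
Compound 2 `Cc1c(OCCCCOc2ccc(C(=O)C(C)C)c(O)c2C)cccc1C(=O)O`: 149 nM
Compound 3 `CCCC(=O)c1ccc(OCCCCOc2ccc(C(=O)O)cc2C)c(C)c1O`: 104 nM

All three were measured in an assay on HEK293 cells for positive allosteric modulation of metabotropic glutamate receptor 2 (Rattus norvegicus), read by thallium flux, with a stated time of 2.5 min; a higher number here means that more compound is needed for the effect, a lower number that less compound is needed. Compound 1 and compound 3 differ in one place, (hydrogen in place of methyl on a saturated chain carbon bound to two saturated chain carbons), and the step of a 1.8-fold lower number from compound 1 to compound 3 (0.27 log units; within the scatter). The difference between the core of compound 1 and the core of compound 2 is not broken down here; their values lie within the scatter of each other.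

Compound 4 `CCC(=O)c1ccc(OCCCCOc2cccc(C(=O)O)c2C)c(C)c1O` is not yet measured. It differs from compound 2 by hydrogen in place of methyl on a saturated chain carbon bound to a carbonyl carbon and a saturated chain carbon, the same kind of change as from compound 1 to compound 3, though the place is not identical: in compound 1 the carbon that loses the methyl is bound to two saturated chain carbons, whereas in compound 2 it is bound to a carbonyl carbon and a saturated chain carbon. Because a 1.8-fold lower number from compound 1 to compound 3 (0.27 log units; within the scatter), a step of similar size is expected from compound 2 to compound 4, a 1.4-fold lower number from compound 2 to compound 4 (0.13 log units; within the scatter). Compound 4 is therefore estimated at 110 nM in this assay, with a range from 50 nM to 250 nM expected.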

Compound 4, half-maximal effective concentration: 62 nM
Estimate against measurement, compound 4: 1.8-fold (0.25 log units) above; measured number inside the range.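

Going from isopropylcarbonyl to propanoyl in this assay gives a 2.4-fold lower number from compound 2 to compound 4 (0.38 log units; beyond the scatter) and is the only one of the two steps that lies beyond the scatter. Set beside the earlier step, the same replacement of methyl by hydrogen runs in the same direction on both cores, and the two sizes do not differ: the same change on two cores in this assay, a 1.8-fold lower number (0.27 log units; within the scatter) from compound 1 to compound 3 and a 2.4-fold lower number (0.38 log units; beyond the scatter) from compound 2 to compound 4, 1.3-fold (0.11 log units) apart, within the scatter of two such steps. This supports carrying the change between these two cores, even though the carbon that loses the methyl is bound differently in each, but two pairs do not show that it would hold on a further core, and they do not explain why the number falls.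

The compounds shown leave open whether trimming the ketone side chain further, to an acetyl group, would continue the trend, or whether a cyclopropyl group on the carbonyl would fit it. They also leave open how an amide or a tetrazole in place of the carboxylic acid would behave in this assay.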